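From 3-chloropyridin-4-yl to 4-methylthiophen-3-yl

The source may hold more compounds than are shown below. What is called first, only, known or untested is meant among the compounds shown, and "the series" means these compounds.

Compound 1 `CC/C(=C(/c1ccc(/C=C/C(=O)O)cc1)c1ccc2[nH]ncc2c1)c1ccccc1C#N` gives 200 ng.h/mL
Compound 2 `CC/C(=C(/c1ccc(/C=C/C(=O)O)cc1)c1ccc2[nH]ncc2c1)c1ccc(C#N)cc1C` gives 4300 ng.h/mL
Compound 3 `CC/C(=C(/c1ccc(/C=C/C(=O)O)cc1)c1ccc2[nH]ncc2c1)c1ccncc1Cl` gives 110 ng.h/mL

These values come from an ADME assay on the whole organism for pharmacokinetics, with Mus musculus as the target, at a dose of 10 mg/kg by the oral route; a higher number here means more compound in the circulation at the dose given, a lower number less compound in the circulation. Compound 3 has the lowest number of the three, though the measurements show a 1.8-fold lower number from compound 1 to compound 3 (0.26 log units; within the scatter), so it cannot be separated from its nearest neighbour. The gap to the top of the set is much wider, with a 39-fold lower number from compound 2 to compound 3 (1.59 log units; beyond the scatter).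

Compound 4 `CC/C(=C(/c1ccc(/C=C/C(=O)O)cc1)c1ccc2[nH]ncc2c1)c1cscc1C` has not yet been measured. It carries 4-methylthiophen-3-yl in place of 3-chloropyridin-4-yl on a double-bonded chain carbon bound to a double-bonded chain carbon and a saturated chain carbon.

Among the compounds with values here, no measured step makes this exact exchange. Changes at this place have ranged from a step within the scatter to a 22-fold higher number from compound 1 to compound 2 (1.33 log units; beyond the scatter), so the place can matter greatly. The entering group shares a methyl with the group of compound 2, which reached 4300 ng.h/mL, but it has no nitrile, and one compound proves little. A rise is therefore expected, estimated as a 5.5-fold higher number from compound 3 to compound 4 (0.74 log units; beyond the scatter). Compound 4 is estimated at 600 ng.h/mL, with an expected range of 130 ng.h/mL to 3000 ng.h/mL.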

Compound 4, area under the concentration-time curve: 3800 ng.h/mL
Estimate against measurement, compound 4: 6.3-fold (0.80 log units) below; the measured number lies above the stated range.
By their numbers in this assay, from the lowest: compounds 3 and 1 (each within the scatter of the next); then compounds 4 and 2 (each within the scatter of the next).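

In this assay, 4-methylthiophen-3-yl at this place gives a 35-fold higher number from compound 3 to compound 4 (1.54 log units; beyond the scatter) and a 19-fold higher number from compound 1 to compound 4 (1.28 log units; beyond the scatter), while the comparison with the other methyl-bearing group shows a 1.1-fold lower number from compound 2 to compound 4 (0.05 log units; within the scatter). A high number here therefore requires neither a nitrile nor a six-membered aromatic ring, and among these compounds the two high numbers belong to the groups carrying a methyl, with no exception so far. No measurement shown here explains why these exchanges move the number so far.

The compounds leave open whether the methyl itself accounts for this split, as no pair here differs by that group alone. They also leave open how an ethyl or a methoxy in its place on the five-membered aromatic ring would read.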